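This account rests on a few compounds, and the source may have more. Where it says the series, first, only, none or still open, it means among the compounds named here.

Values in a functional assay on HepG2 cells (Homo sapiens) for antiproliferative activity, read by MTT assay, with a stated time of 48 h; on this read-out higher numbers stand for weaker inhibition and lower numbers for stronger inhibition:
- compound 1 `COc1cc2oc(-c3ccccc3)cc(=O)c2c(O)c1OCCCCN1CCN(C)CC1` gives 36700 nM
- compound 2 `COc1cc2oc(-c3ccccc3)cc(=O)c2c(O)c1OCCCN1CCCC1` gives 4300 nM
- compound 3 `O=c1cc(-c2ccccc2)oc2cc(OCc3ccccc3)c(OCCCCN3CCCC3)c(O)c12` gives 2000 nM

Compound 3 stands lowest of the three in this assay at 2000 nM, and its gap to each of the other two lies beyond the scatter. Compound 2 is its nearest neighbour and compound 1 its furthest.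

The next compound is compound 4 `COc1cc2oc(-c3ccccc3)cc(=O)c2c(O)c1OCCCCN1CCCC1`, which differs from compound 3 as follows: hydrogen in place of phenyl on a saturated chain carbon bound to an oxygen on an aromatic ring. In words, hydrogen replaces phenyl on a saturated chain carbon bound to an oxygen on an aromatic ring, so benzyloxy becomes methoxy.

Within the data shown here, no measured step covers this change. Among the measured compounds shown here, the one step available is an 8.5-fold lower number from compound 1 to compound 2 (0.93 log units; beyond the scatter), a modest change made at another place, so it shows only how far a single change has moved the numbers. The closest guide is compound 2 at 4300 nM, which also carries methoxy and pyrrolidin-1-yl but has a different chain. Three compounds cannot settle how much that chain matters.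

A modest rise is therefore expected, with a 2.0-fold higher number from compound 3 to compound 4 (0.30 log units; within the scatter) as the estimated step. The estimated value for compound 4 is 4000 nM, within an expected range from 1500 nM to 11000 nM.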

Compound 4, half-maximal inhibitory concentration: 4900 nM
For compound 4 the middle estimate is 1.2-fold (0.09 log units) below the measured one; low and high end bracket the measured number.
By their numbers in this assay, from the lowest: compound 3; then compounds 2 and 4 (each within the scatter of the next); then compound 1.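

In this assay, the change from benzyloxy to methoxy, on a saturated chain carbon bound to an oxygen on an aromatic ring, gives a 2.5-fold higher number from compound 3 to compound 4 (0.39 log units; beyond the scatter), so this position now has a measured step, modest but beyond the scatter, with the rest of the molecule held constant. Among these compounds, the chain can also be read on its own for the first time: with methoxy and the pyrrolidine ring kept, (pyrrolidin-1-yl)methyl in place of pyrrolidin-1-yl gives a 1.1-fold higher number from compound 2 to compound 4 (0.06 log units; within the scatter), so this chain difference does not separate the two compounds in this assay. The amine change can likewise be read with the chain unchanged, as pyrrolidin-1-yl in place of 4-methylpiperazin-1-yl gives a 7.5-fold lower number from compound 1 to compound 4 (0.87 log units; beyond the scatter), which places the large gap in this series on the amine rather than on the chain.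

Nothing measured here offers a reason for any of these steps. Still open, going by these compounds, is whether benzyloxy lowers the number to the same extent on a compound carrying 4-methylpiperazin-1-yl, and how ethoxy at this position, morpholine as the amine or a longer chain would read.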